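The compounds below may be only part of what the source reports. "The series", "measured", "known", "first", "only" and "open" are said of these compounds alone.

Two compounds share one core and differ only in the group on an amine nitrogen in a ring. Compound 1 `CC(=O)N1CCc2c(sc(NC(=O)c3ccc(Oc4ccccc4)cc3)c2C(N)=O)C1` carries an acetyl there; in an ADME assay on RAW264.7 cells (Mus musculus) for cytotoxicity, read by MTT assay, with a stated time of 48 h, tested at 50 uM (a lower number here means less inhibition, a higher number more inhibition at the concentration tested (going by the name of the read-out)), compound 1 gives 32.9%. Compound 2 `CN1CCc2c(sc(NC(=O)c3ccc(Oc4ccccc4)cc3)c2C(N)=O)C1` carries a methyl in the same place, and in this assay compound 2 gives 58.9%. For the measured compounds named here, the single measured step, a number 26 percentage points higher from compound 1 to compound 2 (beyond the scatter), is the whole picture so far, and it leaves compound 2 as the higher of the two numbers, with compound 1 the nearest and lower.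

Compound 3 `CC(C)(C)OC(=O)N1CCc2c(sc(NC(=O)c3ccc(Oc4ccccc4)cc3)c2C(N)=O)C1` has not yet been measured. It differs from compound 2 in one place: tert-butoxycarbonyl in place of methyl on an amine nitrogen in a ring. Going by the values given here, the only step that bears on this change is the acetyl-to-methyl exchange, a number 26 percentage points higher from compound 1 to compound 2 (beyond the scatter), which was modest and ran the other way, ending in the methyl. Putting a larger group back in place of the methyl is expected to send the number down again. The expected step, a number 18.9 percentage points lower from compound 2 to compound 3 (beyond the scatter), would bring the result back toward that of compound 1. Compound 3 is expected to give 40% in this assay, with a range from 25% to 58%.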

Compound 3, a percentage reported as inhibition, at one concentration (the size of the read-out at that concentration, not a potency): 26.9%
Compound 3: middle estimate off by 13.1 percentage points, on the high side; the range from low to high includes it.
By their numbers in this assay, from the lowest: compounds 3 and 1 (each within the scatter of the next); then compound 2.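

Replacing the methyl on the amine nitrogen in the ring with tert-butoxycarbonyl gives a number 32 percentage points lower from compound 2 to compound 3 (beyond the scatter) in this assay and shows that a second group at this position differs clearly from the methyl. Exchanging the methyl of the acetyl for tert-butoxy on the carbonyl carbon gives a number 6 percentage points lower from compound 1 to compound 3 (within the scatter) and so the two groups that join this nitrogen through a carbonyl cannot be told apart here, although the entering tert-butoxy part differs markedly from a methyl. Across these three compounds, the methyl of compound 2 is therefore the one that stands apart, and none of the three goes against that reading, though three compounds make only a very small pattern.

For the compounds shown here, these groups cannot show whether the carbonyl itself goes with the lower numbers, since the only group without one is the methyl, and an ethyl or benzyl group on this nitrogen would test that, as would a urea or a sulfonamide for the carbonyl side. Nothing available here explains the difference between the methyl and the two carbonyl-linked groups.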